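A few compounds are considered here, and "the series" means these few. Any claim that something is new, unique, unknown or untested is made for them only; others in the source may bear on it.

Of the compounds shown here, three have so far been measured in a functional assay on K562 cells (Homo sapiens) for inhibition, read by sulforhodamine B assay, with a stated time of 48 h; a lower number here means a stronger inhibitor of growth, a higher number a weaker inhibitor of growth. Compound 1 `N=C(N)c1ccc(-c2ccc(-c3ccc(Cl)cc3)s2)s1` gives 670 nM. Compound 2 `COc1ccc(-c2ccc(-c3ccc(C(=N)N)o3)o2)cc1` gives 490 nM, and compound 3 `N=C(N)c1ccc(-c2ccc(-c3cc(Cl)cc(Cl)c3)o2)o1` gives 1300 nM. Compound 1 thus stands second highest of the three numbers, with compound 2 its nearest neighbour and compound 3 its furthest, yet both gaps lie within the scatter, so no order among the three can be read from them. Compound 4 `N=C(N)c1ccc(-c2ccc(-c3ccc(F)cc3)s2)s1` has not yet been measured in this assay. It differs from compound 1 by fluoro in place of chloro on an aromatic carbon. For the measured compounds named here, no measured pair shows this change, so nothing beyond the scatter is expected from it. For compound 4 the estimated value in this assay is 900 nM, with a range from 400 nM to 2000 nM. The step this estimate implies is a 1.3-fold higher number from compound 1 to compound 4 (0.13 log units; within the scatter).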

Compound 4, concentration for 50% growth inhibition: 1210 nM
The estimate for compound 4 lay 1.3-fold (0.13 log units) below the measured number; measured number inside the range.
By their numbers in this assay, from the lowest: compounds 2, 1, 4 and 3 (each within the scatter of the next, the first and the last beyond it).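

In this assay, fluoro in place of chloro on an aromatic carbon, para to a large group, gives a 1.8-fold higher number from compound 1 to compound 4 (0.26 log units; within the scatter) and so provides the first pair differing in one place. At this position on the six-membered aromatic ring, the two halogens cannot be told apart in this assay. No supporting evidence bears on this result. On these data alone, whether an amine or a carboxylic acid at this position would give a number beyond the scatter remains open. So does whether the same exchange would stay within the scatter on the core of compound 3.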